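The compounds below may be only part of what the source reports. "The series", "measured", "known", "first", "only" and "open" are said of these compounds alone.

For the measured compounds named here, compound 1, with the structure `COC(=O)C1=C(C)N=C(C)/C(=C(/O)OC)C1c1cccc(OCc2nonc2C)c1`, is one of two compounds measured in an assay on Cortex for displacement of a labelled ligand from Voltage-dependent L-type calcium channel subunit alpha-1D (Rattus norvegicus); on this read-out higher numbers stand for weaker inhibition and lower numbers for stronger inhibition. In this assay compound 1 gives 720 nM, the higher of the two numbers. The other measured compound, compound 2, has the structure `COC(=O)C1=C(C)N=C(C)/C(=C(/O)OC)C1c1ccccc1OCc1c(C)no[n+]1[O-]` and gives 72 nM in this assay; it differs from compound 1 in more than one place, so the two values can only be set side by side, and the gap between them lies beyond the scatter.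

The compound that has not yet been measured is compound 3, with the structure `COC(=O)C1=C(C)N=C(C)/C(=C(/O)OC)C1c1cccc(OCc2nonc2C#N)c1`. It differs from compound 1 in a single change: cyano in place of methyl on an aromatic carbon. Neither measured compound shows what this change does on its own, so no shown step can be leaned on. The change sits on the side ring away from the shared core, and it is expected to leave the number close to that of compound 1, with a step from compound 1 to compound 3 of a 1.1-fold lower number from compound 1 to compound 3 (0.04 log units; within the scatter), in either direction and likely within the scatter. Compound 3 is therefore estimated at 650 nM, with a range from 200 nM to 2000 nM.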

Compound 3, half-maximal inhibitory concentration: 590 nM
Estimate against measurement, compound 3: 1.1-fold (0.04 log units) above; measured number inside the range.
By their numbers in this assay, from the lowest: compound 2; then compounds 3 and 1 (each within the scatter of the next).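

In this assay the move from 4-methyl-1,2,5-oxadiazol-3-yl to 4-cyano-1,2,5-oxadiazol-3-yl gives a 1.2-fold lower number from compound 1 to compound 3 (0.09 log units; within the scatter) and so the two compounds cannot be told apart on this read-out. For the compounds shown here, this is the first direct look at this position, since compound 2 differs from compound 1 in more than one place and could not show what one change here does. The ring carbon next to the ring atom that bears a large group can carry either group with the number staying within the scatter, even though the cyano brings one more heavy atom, a triple bond and a hydrogen-bond acceptor, and no other measurement here helps to explain this match.

On these data alone, one pair of groups at one position says little about the position as a whole, so it remains open whether an amine, a carboxylic acid or a longer chain on this ring carbon would also leave the number in the same place. Also open is what lies behind the lower number of compound 2, which no single-change step among these compounds can separate into its parts.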